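Dichloropurine versus monochloropurine: a chlorine step in the series

A few compounds are considered here, and "the series" means these few. Any claim that something is new, unique, unknown or untested is made for them only; others in the source may bear on it.

Measured compounds in a functional assay on A498 cells (Homo sapiens) for cytotoxicity, read by sulforhodamine B assay, with a stated time of 48 h; a lower number here means that less compound is tolerated, a higher number that more compound is tolerated:
Compound 1 `ClCc1ccccc1Cn1cnc2c(Cl)nc(Cl)nc21` gives 9550 nM.
Compound 2 `ClCc1ccccc1Cn1cnc2c(Cl)ncnc21` gives 58900 nM.
Compound 3 `ClCc1cccc(Cn2cnc3ncnc(Cl)c32)c1` gives 6600 nM.

From compound 2 to compound 1 the change is chloro in place of hydrogen on an aromatic carbon; the step of a 6.2-fold lower number from compound 2 to compound 1 (0.79 log units; beyond the scatter) results. The difference between the core of compound 3 and that of compound 2 is not broken down here. Compound 4 `ClCc1cccc(Cn2cnc3nc(Cl)nc(Cl)c32)c1` is not yet measured; it arises from compound 3 by chloro in place of hydrogen on an aromatic carbon, the same change as from compound 2 to compound 1. Among the measured compounds shown here, for compound 4 a step of a 4.4-fold lower number from compound 3 to compound 4 (0.64 log units; beyond the scatter) is expected, because the earlier step of a 6.2-fold lower number from compound 2 to compound 1 (0.79 log units; beyond the scatter) was the only occurrence of this change so far, with compound 3 as the starting point. Compound 4 is estimated at 1500 nM, with a range from 500 nM to 4500 nM.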

Compound 4, concentration lethal to 50% of the cells: 5370 nM
Beside the measured number, compound 4's estimate is 3.6-fold (0.55 log units) below it; measured number outside the range, above it.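

In this assay, chloro in place of hydrogen on the aromatic carbon between two ring nitrogen atoms gives a 1.2-fold lower number from compound 3 to compound 4 (0.09 log units; within the scatter), so the size of the step does not carry over from one core to the other: the same change on two cores in this assay, a 6.2-fold lower number (0.79 log units; beyond the scatter) from compound 2 to compound 1 and a 1.2-fold lower number (0.09 log units; within the scatter) from compound 3 to compound 4, 5.0-fold (0.70 log units) apart, beyond the scatter of two such steps. The change therefore cannot be treated as a fixed increment across these two cores. With one pair per core, the data do not show which structural difference between the cores accounts for the gap, or what size the step would take on a further core.

Still open, as far as these compounds go, is whether an amine or a methoxy group at that same carbon would give steps that differ between the two cores as chloro does.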